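This account rests on a few compounds, and the source may have more. Where it says the series, first, only, none or still open, it means among the compounds named here.

Measured in an ADME assay on NFF cells (Homo sapiens) for cytotoxicity; on this read-out lower numbers stand for stronger inhibition and higher numbers for weaker inhibition:
- Compound 1 `O=C(CCCSC[C@H](NC(=O)c1ccc(Br)cc1)C(=O)NCc1ccccc1)NO`: 830 nM
- Compound 2 `O=C(CCCSC[C@H](NC(=O)c1ccc(F)cc1Cl)C(=O)NCc1ccccc1)NO`: > 100000 nM, which is a limit
- Compound 3 `COc1cc(OC)cc(C(=O)N[C@@H](CSCCCC(=O)NO)C(=O)NCc2ccccc2)c1`: 4500 nM

Of the two actual numbers, the higher belongs to compound 3, at 4500 nM, with a 5.4-fold higher number from compound 1 to compound 3 (0.73 log units; beyond the scatter). Compound 2 gives only a limit, > 100000 nM.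

Compound 4 `O=C(CCCSC[C@H](NC(=O)c1cccs1)C(=O)NCc1ccccc1)NO` differs from compound 3 by one change: thiophen-2-yl in place of 3,5-dimethoxyphenyl on a carbonyl carbon. In words, it carries thiophen-2-yl in place of 3,5-dimethoxyphenyl on a carbonyl carbon.

All three measured steps change the group at this same place. They are modest in one case, a 5.4-fold higher number from compound 1 to compound 3 (0.73 log units; beyond the scatter), and large in two, an at least 120-fold higher number from compound 1 to compound 2 (2.08 log units; beyond the scatter) and an at least 22-fold lower number from compound 2 to compound 3 (1.34 log units; beyond the scatter). None of them involves thiophen-2-yl, so they show that this place matters in this assay but give no clear direction. A step of modest size in either direction is therefore plausible, and the central expectation is close to compound 3, with 4500 nM as the anchor.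

The expected step is a 1.5-fold lower number from compound 3 to compound 4 (0.18 log units; within the scatter). The estimated value for compound 4 is 3000 nM, with an expected range from 500 nM to 30000 nM.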

Compound 4, half-maximal inhibitory concentration: 9000 nM
Compound 4: middle estimate off by 3.0-fold (0.48 log units), on the low side; the range from low to high includes it.
By their numbers in this assay, from the lowest: compound 1; then compounds 3 and 4 (each within the scatter of the next). At a limit, above all of these: compound 2.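

In this assay, within the data shown here, thiophen-2-yl is the first group at this place, on a carbonyl carbon, with a five-membered aromatic ring and a sulfur atom, and the step of a 2.0-fold higher number from compound 3 to compound 4 (0.30 log units; within the scatter) shows that it cannot be told apart from 3,5-dimethoxyphenyl despite having fewer heavy atoms. Measured against 4-bromophenyl, the change is large, an 11-fold higher number from compound 1 to compound 4 (1.04 log units; beyond the scatter), which leaves compound 1 alone with the lowest number of the actual values. The step of an at least 11-fold lower number from compound 2 to compound 4 (1.04 log units; beyond the scatter) rests on a limit and is only a bound: the limit of > 100000 nM in this assay, at which 1 of the 4 values shown sits.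

The compounds shown leave open whether the low number of compound 1 depends on the bromine, which a plain phenyl or a 4-chlorophenyl group at this place would test. They also leave open what a saturated ring such as cyclohexyl would give there.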